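The source may hold more compounds than are shown below. What is called first, only, known or untested is meant among the compounds shown, and "the series" means these compounds.

Going by the values given here, in a functional assay on cells (Homo sapiens) for antiproliferative activity, read by sulforhodamine B assay, with a stated time of 48 h (a lower number here means a stronger inhibitor, a higher number a weaker inhibitor), two compounds have numbers so far. Compound 1 (`CCCCCCCCCCCCNC(=O)[C@@H]1CSC(c2cc(OC)c(OC)c(OC)c2)N1`) gives 2100 nM and compound 2 (`CCCCCCCCCCNC(=O)[C@@H]1CSC(c2ccc(OC)c(OC)c2)N1`) gives 11900 nM as the higher of the two numbers, which makes compound 2 the weaker inhibitor by a gap beyond the usual scatter. Compound 3 (`CCCCCCCCCCCCNC(=O)[C@@H]1CSC(c2ccc(OC)c(OC)c2)N1`) differs from compound 2 in one place (ethyl in place of hydrogen on a saturated chain carbon, ten or more bonds along the chain from an amide-type nitrogen): ethyl in place of hydrogen on a saturated chain carbon, ten or more bonds along the chain from an amide-type nitrogen. Among the compounds with values here, no measured pair shows this change alone, so any forecast is uncertain. A drop in the number is expected in this assay with compound 1 at 2100 nM as the only lower mark available. The expected change is a 3.4-fold lower number from compound 2 to compound 3 (0.53 log units; beyond the scatter) on this estimate. For compound 3 the estimated value is 3500 nM with an expected range from 1200 nM to 10000 nM in this measurement.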

Compound 3, half-maximal inhibitory concentration: 2900 nM
Compound 3: the middle estimate sits 1.2-fold (0.08 log units) above what was measured; low and high end bracket the measured number.
By their numbers in this assay, from the lowest: compounds 1 and 3 (each within the scatter of the next); then compound 2.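

In this assay, ethyl in place of hydrogen on a saturated chain carbon, ten or more bonds along the chain from an amide-type nitrogen, gives a 4.1-fold lower number from compound 2 to compound 3 (0.61 log units; beyond the scatter) and so lies beyond the scatter, which shows that the assay responds to a change at this position. Hydrogen in place of methoxy on an aromatic carbon gives a 1.4-fold higher number from compound 1 to compound 3 (0.14 log units; within the scatter) and stays within the scatter, so this pair shows no readable difference from that methoxy. Nothing at hand explains either result.

On these data alone, each change rests on a single pair, so it remains open whether the ethyl step would be the same size on the core of compound 1. As far as these compounds go, it is also open whether a longer chain, or a chain ending in an amine or a carboxylic acid, would give a lower or a higher number.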